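A few compounds are considered here, and "the series" means these few. Any claim that something is new, unique, unknown or untested is made for them only; others in the source may bear on it.

Compound 2 `Cc1cccc(-c2c([C@H](C)Nc3nc(N)nc(N)c3C#N)cc3ccc(F)cn3c2=O)c1` gives 89% in an ADME assay on microsomes from liver (Homo sapiens), read by LC-MS, using NADPH, with a stated time of 30 min, tested at 1 uM; a lower number here means that less of the compound is left, a higher number that more of the compound is left; compound 1 `C[C@H](Nc1nc(N)nc(N)c1C#N)c1cc2ccc(F)cn2c(=O)c1-c1ccccc1` gives 87%, and the step of a number 2 percentage points higher from compound 1 to compound 2 (within the scatter) leaves the two within the scatter of each other. Compound 3 `C[C@H](Nc1nc(N)nc(N)c1C#N)c1cc2ccc(F)cn2c(=O)c1-c1ccc(F)cc1` differs from compound 2 by 4-fluorophenyl in place of 3-methylphenyl on an aromatic carbon. Among the measured compounds shown here, no measured step touches the group that changes here; the only step known, a number 2 percentage points higher from compound 1 to compound 2 (within the scatter), concerns a methyl group and was within the scatter. On that basis no step beyond the scatter is expected in this assay, so compound 3 is estimated at 88%, in the range 78% to 96%, an expected step of a number 1 percentage points lower from compound 2 to compound 3 (within the scatter).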

Compound 3, percent of the compound remaining: 87%
Compound 3: the middle estimate sits 1 percentage points above what was measured, and the stated range covers the measured number.
By their numbers in this assay, from the lowest: compounds 1, 3 and 2 (each within the scatter of the next).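

Exchanging 3-methylphenyl for 4-fluorophenyl on this aromatic carbon gives a number 2 percentage points lower from compound 2 to compound 3 (within the scatter) in this assay. Fluoro in place of hydrogen on the phenyl group gives no change at the digits printed from compound 1 to compound 3 (within the scatter), so neither a fluoro nor a methyl substituent separates these three compounds in this read-out. Nothing at hand bears on why these readings stay together.

All three compounds carry a phenyl group at this position. As far as these compounds go, whether an amine, a carboxylic acid or a longer alkyl chain there would stay within the scatter remains open.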